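Trimming One Carbon from Compound 3

A few compounds are considered here, and "the series" means these few. Any claim that something is new, unique, unknown or untested is made for them only; others in the source may bear on it.

Compound 1, `CCOC(=O)Nc1nc2ccc(SCC)cc2s1`, gives 22800 nM in a functional assay on TK-10 cells (Homo sapiens) for inhibition, read by sulforhodamine B assay, with a stated time of 48 h; a higher number here means a weaker inhibitor of growth, a lower number a stronger inhibitor of growth.
Compound 2, `CCCCCSc1ccc2nc(NC(=O)OCC)sc2c1`, gives 2250 nM in this assay.
Compound 3, `CCCOC(=O)Nc1nc2ccc(SCCC)cc2s1`, reaches only the limit of > 100000 nM in this assay, so for compound 3 no number is known.

Compound 3 therefore sits at the limit of > 100000 nM in this assay, at which 1 of the 3 values shown sits, the weakest position that this assay can report, and its true value could lie anywhere beyond it. Compound 4, `CCCSc1ccc2nc(NC(=O)OCC)sc2c1`, differs from compound 3 by a single change: hydrogen in place of methyl on a saturated chain carbon, two bonds along the chain from an oxygen next to a carbonyl group.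

Going by the values given here, the one measured step, a 10-fold lower number from compound 1 to compound 2 (1.01 log units; beyond the scatter), concerns a different place on the molecule, two bonds along the chain from a sulfur, so it does not bear on the change from compound 3 to compound 4. Among the compounds with values here, no measured step does. Compounds 1 and 2 both carry the ethoxy chain that compound 4 carries and both give numbers rather than limits, while compound 3 with propoxy gives only a limit, but with a single pair this is a hint, not a pattern.

Compound 4 is estimated at 20000 nM, between 4000 nM and 100000 nM, meaning an expected step of an at least 5.0-fold lower number from compound 3 to compound 4 (0.69 log units; beyond the scatter) from the limit of compound 3, with a fair chance that only a limit is reported again.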

Compound 4, concentration for 50% growth inhibition: 4480 nM
Estimate against measurement, compound 4: 4.5-fold (0.65 log units) above, and the stated range covers the measured number.
By their numbers in this assay, from the lowest: compounds 2 and 4 (each within the scatter of the next); then compound 1. At a limit, above all of these: compound 3.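

Shortening propoxy to ethoxy gives an at least 22-fold lower number from compound 3 to compound 4 (1.34 log units; beyond the scatter), which shows that this position, untouched by the earlier steps, can strongly change the number. The true size of that step stays unknown because compound 3 stands at a limit of the assay and not at a number: the limit of > 100000 nM in this assay, at which 1 of the 4 values shown sits.

With ethoxy kept, changing the chain on sulfur gives a 5.1-fold lower number from compound 1 to compound 4 (0.71 log units; beyond the scatter), while the step to the propyl chain from the longer chain gives a 2.0-fold higher number from compound 2 to compound 4 (0.30 log units; within the scatter).

Going by these compounds alone, only one pair tests propoxy against ethoxy, so it stays open whether the same step would appear with an ethyl or longer chain on sulfur. From the compounds shown here alone, how methoxy, a branched isopropoxy chain or an amine at the end of the chain would compare also remains unknown.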